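This account rests on a few compounds, and the source may have more. Where it says the series, first, only, none or still open, it means among the compounds named here.

Measured in a functional assay on A549 cells (Homo sapiens) for antiproliferative activity, read by MTT assay, with a stated time of 48 h; a higher number here means a weaker inhibitor, a lower number a stronger inhibitor:
- compound 1 `COc1cc(-c2nnc3c(OC)cc(-c4ccc5[nH]ccc5c4)cn23)cc(OC)c1OC`: 167 nM
- compound 2 `COc1cc(-c2nnc3c(OC4COC4)cc(-c4ccc5[nH]ccc5c4)cn23)cc(OC)c1OC`: 9810 nM
- compound 3 `COc1cc(-c2nnc3c(OCC(F)(F)F)cc(-c4ccc5[nH]ccc5c4)cn23)cc(OC)c1OC`: 585 nM

Compound 3 holds the middle place of these three numbers. Compound 4 `COc1cc(-c2nnc3c(OC4CC4)cc(-c4ccc5[nH]ccc5c4)cn23)cc(OC)c1OC` has cyclopropyl in place of 2,2,2-trifluoroethyl on an oxygen on an aromatic ring. All three measured steps change the group at this same place. The modest one is a 3.5-fold higher number from compound 1 to compound 3 (0.54 log units; beyond the scatter). The large ones are a 59-fold higher number from compound 1 to compound 2 (1.77 log units; beyond the scatter) and a 17-fold lower number from compound 2 to compound 3 (1.22 log units; beyond the scatter). Oxetan-3-yl, which gave 9810 nM in compound 2, is the only ring measured here, so a small upward move is expected, though three compounds are thin guidance. The estimated step is a 1.2-fold higher number from compound 3 to compound 4 (0.08 log units; within the scatter). Compound 4 is expected at 700 nM, within an estimated range of 170 nM to 3500 nM.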

Compound 4, half-maximal inhibitory concentration: 198 nM
Estimate against measurement, compound 4: 3.5-fold (0.55 log units) above; low and high end bracket the measured number.
By their numbers in this assay, from the lowest: compounds 1 and 4 (each within the scatter of the next); then compound 3; then compound 2.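

In this assay, cyclopropyl gives a 3.0-fold lower number from compound 3 to compound 4 (0.47 log units; beyond the scatter) and a 50-fold lower number from compound 2 to compound 4 (1.70 log units; beyond the scatter), so a ring at this place does not by itself go with the weak number of compound 2. The step to cyclopropyl from methyl is a 1.2-fold higher number from compound 1 to compound 4 (0.07 log units; within the scatter) and does not separate the two groups, which means a group larger than methyl can stand on this oxygen without a measurable loss. Nothing available here accounts for these differences.

The compounds shown leave open how a longer chain such as butyl, a larger carbon ring such as cyclohexyl, or a chain ending in an amine would fare on this oxygen.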